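Amide nitrogen substituent changes on a shared core

The source may hold more compounds than are shown below. What is called first, only, known or untested is meant among the compounds shown, and "the series" means these compounds.

Measured so far:
compound 1: `COc1cccc2cc(C(=O)NC3CCCCC3)c(=N)oc12` — > 70%
compound 2: `N=c1oc2ccc(Br)cc2cc1C(=O)NCCCO` — 25%
compound 3: `COc1cccc2cc(C(=O)Nc3c(C#N)ncn3-c3ccccc3)c(=N)oc12` — 9%

All three were read in an assay on HEK293 cells for displacement of a labelled ligand from adenosine receptor A2b (Homo sapiens), read by scintillation counting, with a stated time of 30 min, tested at 10 uM; a lower number here means less inhibition, a higher number more inhibition at the concentration tested (going by the name of the read-out). Compound 1 gives only a limit of the assay, > 70%, so where it stands is known as the limit of > 70% in this assay, at which 1 of the 3 values shown sits, and not as a number. Within the data shown here, compound 2 gives 25% and compound 3 gives 9%; each differs from compound 1 in more than one place, so no single-change step among the measured compounds exists and their values can only be read side by side.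

Compound 4 is `COc1cccc2cc(C(=O)NCCO)c(=N)oc12`, not yet measured in this assay. Against compound 1 the change is 2-hydroxyethyl in place of cyclohexyl on an amide-type nitrogen. A fall in the read-out is expected, since compound 2 also carries a short hydroxyl-bearing chain on its amide nitrogen and gives 25%; compound 2 differs in its core as well, so this is a pointer, not a measured step. The step of a number at least 40 percentage points lower from compound 1 to compound 4 (beyond the scatter) is expected to be a drop beyond the usual scatter, its size uncertain while compound 1 is known only as a limit. Compound 4 is expected to give about 30%, within 10% to 55%.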

Compound 4, a percentage reported as inhibition, at one concentration (the size of the read-out at that concentration, not a potency): 65%
For compound 4 the middle estimate is 35 percentage points below the measured one, and the stated range ends below it.
By their numbers in this assay, from the lowest: compound 3; then compound 2; then compound 4. At a limit, above all of these: compound 1.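

In this assay, among these compounds, compound 4 gives 65% with 2-hydroxyethyl on the amide-type nitrogen, so on the shared core a substituent with no ring still carries a sizeable read-out at this position, which the earlier compounds, each differing from the others in more than one place, could not show. Compound 1 stands at > 70% in this assay and that value is a limit of the assay, not a number. The change from cyclohexyl to 2-hydroxyethyl therefore reads only as a number at least 5 percentage points lower from compound 1 to compound 4 (that floor lies within the scatter) and the true size of the fall remains unsettled, the reading being bounded by this: the limit of > 70% in this assay, at which 1 of the 4 values shown sits.

The compounds shown do not separate the contribution of the hydroxyl from that of the short chain carrying it, and a plain ethyl group, a longer hydroxyalkyl chain or a chain ending in an amine or a carboxylic acid on this core would address that. Going by these compounds, how the read-out responds to smaller rings than cyclohexyl at this position also stays open, as does a number for compound 1 itself.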